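Swapping the Aryl Group on the Piperazine Nitrogen

The source may hold more compounds than are shown below. What is called first, only, known or untested is meant among the compounds shown, and "the series" means these compounds.

Compound 2 `CCCc1ccccc1N1CCN(CCCNc2ncccc2C(=O)N(C)C)CC1` gives 31.6 nM in a functional assay on aorta for antagonist activity at Alpha-1D adrenergic receptor (Rattus norvegicus); a higher number here means weaker binding, a lower number tighter binding. Among the two compounds measured so far it has the highest number, yet its nearest neighbour, compound 1 `CN(C)C(=O)c1cccnc1NCCCN1CCN(c2ccccc2)CC1`, with 15.9 nM, lies within the scatter of it: the step of a 2.0-fold higher number from compound 1 to compound 2 (0.30 log units; within the scatter) is too small to count as a change. Compound 3 `COc1cc(O)ccc1N1CCN(CCCNc2ncccc2C(=O)N(C)C)CC1` has not yet been measured. It differs from compound 2 in 4-hydroxy-2-methoxyphenyl in place of 2-propylphenyl on an amine nitrogen in a ring. Within the data shown here, no measured step bears directly on this exchange; the only step in hand concerns a propyl in place of hydrogen on the same ring and stayed within the scatter. The exchange is therefore expected to move the number little, if at all, beyond the scatter, so the step of a 1.4-fold lower number from compound 2 to compound 3 (0.16 log units; within the scatter) is estimated as small. For compound 3 the expected value in this assay is 22 nM, with a range from 5 nM to 90 nM.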

Compound 3, dissociation constant: 79.4 nM
Beside the measured number, compound 3's estimate is 3.6-fold (0.56 log units) below it; measured number inside the range.
By their numbers in this assay, from the lowest: compounds 1 and 2 (each within the scatter of the next); then compound 3.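

In this assay, the aryl group on this amine nitrogen in a ring now produces a change that counts: a 2.5-fold higher number from compound 2 to compound 3 (0.40 log units; beyond the scatter) with 4-hydroxy-2-methoxyphenyl in place of 2-propylphenyl, and a 5.0-fold higher number from compound 1 to compound 3 (0.70 log units; beyond the scatter) with the same group in place of phenyl. Among these compounds, the earlier pair had stayed within the scatter, so this is the first sign that what the aromatic ring carries can shift the number here, and both new steps run towards a higher number. Nothing available explains this shift.

The exchange brings in a hydroxy and a methoxy group together, so the compounds shown cannot tell which of the two accounts for the steps. Going by these compounds, it also remains open whether a methoxy group alone, or a chlorine atom on the same ring, would stay with compound 1 and compound 2 or move as compound 3 does.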